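The source may report more compounds than this note shows. Statements on the series, on what has been measured and on what is new or still open speak of the compounds shown alone.

Measured so far, in an assay on Sf9 cells for inhibition of protein deacetylase HDAC6 (Homo sapiens), read by fluorescence, with a stated time of 40 min; a higher number here means a weaker inhibitor, a lower number a stronger inhibitor:
- compound 1, `COc1ccc(-c2nc(CNc3ccc(C(=O)NO)cc3)n(-c3ccccc3)n2)cc1`, gives 163 nM
- compound 2, `Cc1ccc(-c2nc(CNc3ccc(C(=O)NO)cc3)n(-c3ccccc3)n2)s1`, gives 30.6 nM
- compound 3, `O=C(NO)c1ccc(NCc2nc(-c3ccc(Cl)cc3)nn2-c2ccccc2)cc1`, gives 181 nM

Compound 3 has the highest of the three numbers. Its nearest neighbour is compound 1, separated by a 1.1-fold higher number from compound 1 to compound 3 (0.05 log units; within the scatter); its furthest is compound 2, separated by a 5.9-fold higher number from compound 2 to compound 3 (0.77 log units; beyond the scatter).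

Compound 4, `Cc1ccsc1-c1nc(CNc2ccc(C(=O)NO)cc2)n(-c2ccccc2)n1`, has not yet been measured. It differs from compound 3 in one place: 3-methylthiophen-2-yl in place of 4-chlorophenyl on an aromatic carbon.

Among the measured compounds shown here, two measured steps bear on this change. Going from a six-membered aromatic ring of carbon only to a methylthiophenyl gave a 5.3-fold lower number from compound 1 to compound 2 (0.73 log units; beyond the scatter), and the reverse exchange gave a 5.9-fold higher number from compound 2 to compound 3 (0.77 log units; beyond the scatter). Both point the same way: the thiophene bearer gives the lower number. The group entering compound 4 is 3-methylthiophen-2-yl, not the 5-methylthiophen-2-yl of compound 2, so the size of the step is less certain than its direction. The expectation for compound 4 is therefore a lower number than compound 3, by about a 2.6-fold lower number from compound 3 to compound 4 (0.41 log units; beyond the scatter), in this assay. Compound 4 is estimated at 70 nM, with a range from 25 nM to 200 nM.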

Compound 4, half-maximal inhibitory concentration: 30.7 nM
Estimate against measurement, compound 4: 2.3-fold (0.36 log units) above, and the stated range covers the measured number.
By their numbers in this assay, from the lowest: compounds 2 and 4 (each within the scatter of the next); then compounds 1 and 3 (each within the scatter of the next).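

In this assay, 3-methylthiophen-2-yl and 5-methylthiophen-2-yl cannot be told apart on this aromatic carbon between two ring nitrogen atoms (a 1.0-fold higher number from compound 2 to compound 4 (0.00 log units; within the scatter)). The lower number of the thiophene bearer therefore holds for two placements of the methyl group, against both the 4-chlorophenyl (a 5.9-fold lower number from compound 3 to compound 4 (0.77 log units; beyond the scatter)) and the 4-methoxyphenyl (a 5.3-fold lower number from compound 1 to compound 4 (0.73 log units; beyond the scatter)), with only these four compounds to go on. Nothing measured here accounts for this result.

As far as these compounds go, whether plain thiophen-2-yl, with no methyl group, or a furan-2-yl ring would give a number in the same range stays open. So does whether the thiophene bearer would keep its lower number with a methyl group in place of the phenyl group on the ring nitrogen.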